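The source may hold more compounds than are shown below. What is called first, only, known or untested is meant among the compounds shown, and "the series" means these compounds.

Series notes, trimethoxyphenyl to dimethoxyphenyl step.

Compound 1 `COc1ccc(C(=O)/C=C/c2cc(-c3cc(OC)c(OC)c(OC)c3)n3nc(-c4ccccc4)cc3n2)cc1` gives 13200 nM in a functional assay on MDA-MB-231 cells (Homo sapiens) for antiproliferative activity, read by MTT assay, with a stated time of 24 h; on this read-out higher numbers stand for weaker inhibition and lower numbers for stronger inhibition. Compound 2 `COc1cc(-c2cc(/C=C/C(=O)c3ccc(C)cc3)nc3cc(-c4ccccc4)nn23)cc(OC)c1OC` gives 23900 nM and compound 3 `COc1cc(-c2cc(/C=C/C(=O)c3ccccc3)nc3cc(-c4ccccc4)nn23)cc(OC)c1OC` gives 15800 nM. Compound 1 holds the lowest of the three numbers, but both neighbours sit within the scatter of it, so no order among the three can be claimed.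

The measured steps all change the aryl ketone side: a 1.8-fold higher number from compound 1 to compound 2 (0.26 log units; within the scatter); a 1.2-fold higher number from compound 1 to compound 3 (0.08 log units; within the scatter); a 1.5-fold lower number from compound 2 to compound 3 (0.18 log units; within the scatter). Each step stays within the scatter, so on that ring the substituent has not moved the number.

Compound 4 `COc1ccc(C(=O)/C=C/c2cc(-c3ccc(OC)c(OC)c3)n3nc(-c4ccccc4)cc3n2)cc1` differs from compound 1 elsewhere: hydrogen in place of methoxy on an aromatic carbon. Among the measured compounds shown here, no measured pair touches the trimethoxyphenyl ring, so none of the steps above bears directly on this change. For the measured compounds named here, the only guidance is that small aromatic edits have so far left this assay unchanged beyond the scatter, which argues against expecting a large move.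

For compound 4 a number close to compound 1 is expected, leaning towards a higher value, with the step of a 1.5-fold higher number from compound 1 to compound 4 (0.18 log units; within the scatter) estimated as within or near the scatter. Going by the values given here, the estimate for compound 4 is 20000 nM, within a range of 8000 nM to 60000 nM, the width reflecting that this ring has no measured step behind it.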

Compound 4, half-maximal inhibitory concentration: 13900 nM
Estimate against measurement, compound 4: 1.4-fold (0.16 log units) above, within the range that was stated.
By their numbers in this assay, from the lowest: compounds 1, 4, 3 and 2 (each within the scatter of the next).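

Among the compounds shown here, replacing the 3,4,5-trimethoxyphenyl group with the 3,4-dimethoxyphenyl group gives the first measured step on this ring: in this assay the change reads a 1.1-fold higher number from compound 1 to compound 4 (0.02 log units; within the scatter). For the compounds shown here, a methoxy on this aromatic carbon, ortho to a methoxy group and meta to a large group, can therefore give way to hydrogen with no change beyond the scatter, something the earlier steps, all on the aryl ketone side, could not show. No measured evidence speaks to the reason for this result.

Still open, from the compounds shown here alone, is whether this position accepts anything other than methoxy or hydrogen, such as an amine, a carboxylic acid or a longer alkoxy chain. Also open, going by these compounds, is whether the same edit gives the same result with the aryl ketone of compound 2 or compound 3 in place of that of compound 1, since this single step was read only against the methoxy-bearing ketone.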